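The source may hold more compounds than are shown below. What is called first, only, known or untested is meant among the compounds shown, and "the series" means these compounds.

Two compounds of this series have been run in a functional assay on SN12C cells (Homo sapiens) for cytotoxicity, read by sulforhodamine B assay, with a stated time of 48 h, tested at 100 nM; a lower number here means a stronger effect, a higher number a weaker effect of the compound at the concentration tested. Compound 1 `Cc1cc(O)cc(-c2nn(CC#N)cc2-c2ccnc(-c3ccc(Oc4ccccc4)cc3)c2)c1` gives 86%, while compound 2 `COc1cc(C)cc(-c2nn(CC#N)cc2-c2ccnc(-c3ccc(N(C)C)cc3)c2)c1` gives 44%, the lower of the two numbers and well apart from compound 1. Compound 3 `Cc1cc(O)cc(-c2nn(CC#N)cc2-c2ccnc(-c3ccc(N(C)C)cc3)c2)c1` is not yet measured; it differs from compound 2 in one place: hydrogen in place of methyl on an oxygen on an aromatic ring. Within the data shown here, no measured pair isolates this change, so the size of its step in this assay is uncertain; a modest weakening is expected, a number 11 percentage points higher from compound 2 to compound 3 (beyond the scatter). For compound 3 the estimate is 55%, within 35% to 80%.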

Compound 3, a percentage reported as activity, at one concentration (the size of the read-out at that concentration, not a potency): 91%
Beside the measured number, compound 3's estimate is 36 percentage points below it; the whole stated range lies below it.
By their numbers in this assay, from the lowest: compound 2; then compounds 1 and 3 (each within the scatter of the next).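

In this assay, methoxy to hydroxy on the 3-methoxy-5-methylphenyl group is a large loss (a number 47 percentage points higher from compound 2 to compound 3 (beyond the scatter)), so the effect at this position is highly sensitive to this single change. With hydroxy in place, dimethylamino in place of phenoxy on an aromatic carbon leaves the number within the scatter (a number 5 percentage points higher from compound 1 to compound 3 (within the scatter)). No evidence on hand accounts for the methoxy to hydroxy step.

Still open, on these data alone, is whether phenoxy and dimethylamino also match when methoxy is present. As far as these compounds go, whether an ethoxy group or an amine at this position retains the effect of methoxy also remains open.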